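The source may report more compounds than this note shows. Statements on the series, on what has been measured and on what is new or still open speak of the compounds shown alone.

Compound 1 `CC1=C(C[Se]C(=O)c2ccccc2)C(=O)c2ccccc2C1=O` reaches only the limit of an ADME assay on Vero cells (Chlorocebus sabaeus) for cytotoxicity, read by MTT assay, with a stated time of 24 h (on this read-out lower numbers stand for higher toxicity in this test and higher numbers for lower toxicity in this test), giving > 50000 nM. Among the compounds with values here, compound 2 `CC1=C(C[Se]C(=O)c2ccccc2C)C(=O)c2ccccc2C1=O` holds the sole number in this assay, at 7700 nM. Within the data shown here, the one measured step is an at least 6.4-fold lower number from compound 1 to compound 2 (0.81 log units; beyond the scatter), and it rests on the limit (the limit of > 50000 nM in this assay, at which 1 of the 2 values shown sits). Compound 3 `CC1=C(C[Se]C(=O)c2ccc(F)cc2)C(=O)c2ccccc2C1=O` differs from compound 2 by 4-fluorophenyl in place of 2-methylphenyl on a carbonyl carbon. Among the measured compounds shown here, no measured step covers this exchange, so the direction is uncertain. Compound 3 is expected to show a move back toward lower toxicity of about a 2.6-fold higher number from compound 2 to compound 3 (0.41 log units; beyond the scatter). Compound 3 is therefore estimated at 20000 nM, within 6000 nM to 60000 nM.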

Compound 3, half-maximal cytotoxic concentration: > 50000 nM
Compound 3: no number, only a limit; the forecaster's own chance of this, stated with the estimate: 35%; at least 2.5-fold (0.39 log units) between middle value and limit.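

In this assay, 4-fluorophenyl in place of 2-methylphenyl on a carbonyl carbon whose other neighbour is selenium gives an at least 6.4-fold higher number from compound 2 to compound 3 (0.81 log units; beyond the scatter). Among the three compounds, only the one carrying 2-methylphenyl gives a number, and a fluoro on the aromatic ring does not bring the value off the limit. Compound 1 and compound 3 both rest on a limit, so the step between them cannot be read: the limit of > 50000 nM in this assay, at which 2 of the 3 values shown sit.

From the compounds shown here alone, it remains open whether a chloro, a methoxy or an amine on that aromatic ring would also give a number rather than a limit.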